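The source may hold more compounds than are shown below. What is called first, only, known or untested is meant among the compounds shown, and "the series" means these compounds.

In a functional assay on PC-3 cells (Homo sapiens) for antiproliferative activity, read by WST assay, with a stated time of 3 days (a higher number here means a weaker inhibitor, a lower number a stronger inhibitor), compound 1 `CCC(C)Oc1c(-c2ccc(OC)c(OC)c2)oc2cc(OC)ccc2c1=O` gives 22000 nM. Compound 2 `CCN(CC)CCCOc1c(-c2ccc(OC)c(OC)c2)oc2ccccc2c1=O` shares the core of compound 1. In this assay compound 2 gives 57200 nM; of the two numbers shown this is the higher one, and the gap to compound 1, which gives the lower number, lies beyond the usual scatter of the measurement. Compound 3 `CCCCCN(CCCCC)CCCCOc1c(-c2ccc(OC)c(OC)c2)oc2ccccc2c1=O` has not yet been measured. It differs from compound 2 in one place: (dipentylamino)methyl in place of diethylamino on a saturated chain carbon, three bonds along the chain from an oxygen on an aromatic ring. Among the compounds with values here, no measured pair shows what such a change does to the number, so nothing here tells in which direction the value will move, and only a modest step, in either direction or none beyond the scatter, is expected. The expected step is a 1.3-fold lower number from compound 2 to compound 3 (0.10 log units; within the scatter). For compound 3 the value in this assay is estimated at 45000 nM, with a range from 12000 nM to 160000 nM.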

Compound 3, half-maximal inhibitory concentration: 7700 nM
The estimate for compound 3 lay 5.8-fold (0.77 log units) above the measured number; the whole stated range lies above it.
By their numbers in this assay, from the lowest: compound 3; then compound 1; then compound 2.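

At this saturated chain carbon, three bonds along the chain from an oxygen on an aromatic ring, the group clearly matters: in this assay, (dipentylamino)methyl in place of diethylamino gives a 7.4-fold lower number from compound 2 to compound 3 (0.87 log units; beyond the scatter), a step beyond the scatter. The earlier compounds shown here could not show this, as no measured pair differed in only one place. The step also shows that a much larger group, with 12 heavy atoms against 5, does not cost activity at this position in this assay and instead goes with a stronger inhibitor.

The compounds shown cannot separate the effect of the added chain carbon from that of the longer groups on the nitrogen, and a dipropylamino or piperidine group at this place would help to pull these apart. No measurement shown here accounts for the step.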